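Two Ring Stereocentres Reversed: From Compound 1 to Compound 3

This account rests on a few compounds, and the source may have more. Where it says the series, first, only, none or still open, it means among the compounds named here.

Compound 1 `C=C1CCCC(C)(C)C1CC[C@]1(C)CC[C@@H]([C@@H](C)C(=O)O)OO1` is described in a functional assay on NCI-H460 cells (Homo sapiens) for inhibition (a lower number here means a stronger inhibitor of growth, a higher number a weaker inhibitor of growth), only by a limit: compound 1 is reported as > 10000 nM, a limit of the assay and not a number. It therefore stands at the limit of > 10000 nM in this assay, at which 1 of the 2 values shown sits. A related compound, compound 2 `C=C1CCC[C@H]2[C@](C)(CC[C@]3(C)CC[C@@H]([C@@H](C)C(=O)O)OO3)[C@@H](C)CC[C@]12C`, carries a larger carbon skeleton; in this assay compound 2 gives 600 nM, a numerical value where compound 1 gives none. For the measured compounds named here, no step between these two measured compounds is given, so only their two values can be read.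

Compound 3 `C=C1CCCC(C)(C)C1CC[C@@]1(C)CC[C@H]([C@@H](C)C(=O)O)OO1` has not yet been measured. It differs from compound 1 in this way: the two compounds have the same atoms and bonds; at least one stereo element is drawn with a configuration in one of them and without one in the other: 2 of 4 stereo elements differ; a stereocentre at a saturated ring carbon is drawn R in compound 1 and S in compound 3; a stereocentre at a saturated ring carbon is drawn S in compound 1 and R in compound 3. Going by the values given here, no measured step shows how large such a change is in this assay, nor in which direction it runs. Compound 3 is expected to remain near the limit, with an estimated value of 10000 nM (range 3000 nM to 30000 nM). The step of a number no higher from compound 1 to compound 3 (the limit leaves the size open) is expected to stay within the scatter.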

Compound 3, concentration for 50% growth inhibition: 1830 nM
Compound 3: the middle estimate sits 5.5-fold (0.74 log units) above what was measured; the whole stated range lies above it.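

In this assay, reversing the two saturated ring stereocentres with atoms and bonds unchanged gives an at least 5.4-fold lower number from compound 1 to compound 3 (0.73 log units; beyond the scatter). For the compounds shown here, the earlier compounds offered no step at all, so this is the first measured sign that configuration at these ring carbons alone can carry the smaller skeleton from a limit of the assay to a numerical value. The size of the step is only a lower bound: the limit of > 10000 nM in this assay, at which 1 of the 3 values shown sits.

Which of the two ring stereocentres accounts for the step stays open, and the comparison itself is qualified: the fact that one of compounds 1 and 3 is drawn with a defined configuration and the other without, at the place where they differ Whether the same reversal would hold with a methyl ester in place of the carboxylic acid, or on the larger carbon skeleton of compound 2, also remains open.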